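Swapping an aminopropoxy group for bromine on a flavone

This account rests on a few compounds, and the source may have more. Where it says the series, first, only, none or still open, it means among the compounds named here.

Measured compounds:
Compound 1, `COc1cc(OC)c2c(=O)cc(-c3ccc(OCCF)cc3)oc2c1`, in a functional assay (Homo sapiens) for antiproliferative activity, read by resazurin assay, with a stated time of 48 h, tested at 5 uM (a higher number here means a stronger effect of the compound at the concentration tested, a lower number a weaker effect), compound 1 gives "not active" (no number reported).
Compound 2, `COc1cc(OC)c2c(=O)cc(-c3ccc(OC4CCN(C)CC4)cc3)oc2c1`, in this assay compound 2 gives 28%.
Compound 3, `COc1cc(OC)c2c(=O)cc(-c3ccc(OCCCN)cc3)oc2c1`, in this assay compound 3 gives 22%.

Compound 3 holds the lower of the two numbers, but its gap to compound 2, a number 6 percentage points lower from compound 2 to compound 3 (within the scatter), is within the scatter, so the two cannot be ordered. Compound 1, which carries no amine on its side chain, was not active.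

Compound 4, `COc1cc(OC)c2c(=O)cc(-c3ccc(Br)cc3)oc2c1`, differs from compound 3 in one place: bromo in place of 3-aminopropoxy on an aromatic carbon. Going by the values given here, the only measured step, from compound 2 to compound 3, exchanges one amine-bearing group for another and does not speak to the loss of the nitrogen altogether. Compound 1 is the nearest guide: a side chain without an amine gave no activity. The expectation is therefore a drop in this assay for compound 4, estimated as a number 14 percentage points lower from compound 3 to compound 4 (beyond the scatter). Compound 4 is expected to give about 8%, within 0% to 22%.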

Compound 4, a percentage reported as inhibition, at one concentration (the size of the read-out at that concentration, not a potency): 12%
For compound 4 the middle estimate is 4 percentage points below the measured one, and the stated range covers the measured number.
By their numbers in this assay, from the lowest: compounds 4, 3 and 2 (each within the scatter of the next, the first and the last beyond it).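

Replacing the side chain with a single bromo atom gives a number 10 percentage points lower from compound 3 to compound 4 (within the scatter) in this assay, so this step alone does not show that the 3-aminopropoxy group matters at this position. The comparison with the bulkier amine-bearing group is clearer, with a number 16 percentage points lower from compound 2 to compound 4 (beyond the scatter) in the same assay, so (1-methylpiperidin-4-yl)oxy outperforms bromo on this aromatic carbon, though only modestly. No measurement shown here explains these differences.

The compounds leave open whether a longer chain ending in an amine, or a dimethylamino group at the end of the same propoxy chain, would raise the number further. They also leave open whether chloro or a plain hydrogen at this position would read like bromo.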